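Swapping methyl for ethoxycarbonyl on a weakly active core

The source may report more compounds than this note shows. Statements on the series, on what has been measured and on what is new or still open speak of the compounds shown alone.

Measured compounds:
- compound 1, `c1ccc(/N=c2\ssnc2-c2ccccc2)cc1`, in a functional assay on MCF7 cells (Homo sapiens) for antiproliferative activity, read by MTT assay, with a stated time of 72 h; a lower number here means a stronger inhibitor of growth, a higher number a weaker inhibitor of growth: 10000 nM
- compound 2, `c1ccc(/N=c2\ssnc2-c2cccs2)cc1`, in this assay: > 10000 nM
- compound 3, `Cc1nss/c1=N\c1ccccc1`, in this assay: > 10000 nM

Compound 1 gives 10000 nM in this assay. For compound 2 the value > 10000 nM is a limit of the assay and not a number. For compound 3 the value > 10000 nM is likewise a limit and not a number, so compound 3 stands at the top of the range that this assay can report; the same holds for compound 2, as the limit of > 10000 nM in this assay, at which 2 of the 3 values shown sit, records.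

Compound 4 has the structure `CCOC(=O)c1nss/c1=N\c1ccccc1`. It differs from compound 3 by ethoxycarbonyl in place of methyl on an aromatic carbon.

Of the measured steps, a number no lower from compound 1 to compound 3 (the limit leaves the size open) and a number no lower from compound 1 to compound 2 (the limit leaves the size open) touch the same position, but both end at a limit and their size cannot be read. The step that the two limits leave unreadable from compound 2 to compound 3 is unreadable for the same reason. Within the data shown here, no measured step changes methyl into ethoxycarbonyl, so the direction of a number no higher from compound 3 to compound 4 (the limit leaves the size open) is a guess.

Compound 4 is therefore expected to stay near the limit, estimated at 10000 nM with a range from 3000 nM to 30000 nM.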

Compound 4, concentration for 50% growth inhibition: > 10000 nM
Compound 4 ended at the assay's limit; the forecaster's own chance of this, stated with the estimate: 70%; the middle value lies on the limit itself.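

Ethoxycarbonyl, which unlike methyl brings hydrogen-bond acceptors to this aromatic carbon next to the ring nitrogen, still leaves compound 4 at > 10000 nM in this assay, and this value is a limit of the assay and not a number. Phenyl therefore remains the only group at this position with a readable value, giving a number no lower from compound 1 to compound 4 (the limit leaves the size open), while the steps from compound 2 and compound 3 to compound 4 cannot be read. With a fourth group tested here, the values gather further at the top of the range that can be reported: the limit of > 10000 nM in this assay, at which 3 of the 4 values shown sit.

From the compounds shown here alone, how far compound 2, compound 3 and compound 4 lie from one another beyond that limit stays unknown, so ethoxycarbonyl, methyl and thiophen-2-yl cannot be ranked. Going by these compounds, it also remains open whether an amine or a carboxylic acid on this carbon would give a readable value, as phenyl does in compound 1.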